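The compounds below may be only part of what the source reports. "The series", "measured", "known", "first", "only" and "open" are said of these compounds alone.

The measured compounds:
compound 1 `CN1Cc2ccc(OCc3ccc(-c4ccccc4)cc3)cc2[C@@H](O)C1`, in an ADME assay on Vero cells (Chlorocebus sabaeus) for cytotoxicity, read by sulforhodamine B assay, with a stated time of 72 h (a higher number here means a weaker inhibitor, a lower number a stronger inhibitor), compound 1 gives 23000 nM
compound 2 `CN1Cc2ccc(OCCCn3ccnc3[N+](=O)[O-])cc2[C@@H](O)C1`, compound 2 gives > 50000 nM, a limit of the assay and not a number

Going by the values given here, compound 1 stands as the only compound with a numerical value in this assay. Compound 2 sits at the limit of > 50000 nM in this assay, at which 1 of the 2 values shown sits, so nothing more than that limit is known for it.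

Compound 3 `CN1Cc2ccc(OCc3ccc(Br)cc3)cc2[C@@H](O)C1` has not been measured in this assay. It differs from compound 1 in one place: bromo in place of phenyl on an aromatic carbon. Among the compounds with values here, no step between two measured compounds is available to guide the size of the change, so the expectation rests on compound 1 alone. A small move toward a higher number, or none beyond the usual scatter, is expected in this assay. Compound 3 is estimated at about 35000 nM, with a range from 15000 nM to 80000 nM. That estimate means an expected step of a 1.5-fold higher number from compound 1 to compound 3 (0.18 log units; within the scatter).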

Compound 3, half-maximal inhibitory concentration: 37000 nM
For compound 3 the middle estimate is 1.1-fold (0.02 log units) below the measured one; low and high end bracket the measured number.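

In this assay, putting bromo in place of phenyl on an aromatic carbon, para to a large group, gives a 1.6-fold higher number from compound 1 to compound 3 (0.21 log units; within the scatter). Going by these compounds alone, this is the first direct comparison at this position, and it shows that a single bromine atom can stand where a six-carbon aromatic ring stood while the two values remain indistinguishable in this read-out. Nothing shown here accounts for this result, and one swap at one position supports no wider rule.

The compounds shown leave open whether a different kind of group on this aromatic carbon, such as an amine or a carboxylic acid, would also give a value close to those of compound 1 and compound 3 in this assay. They also leave open whether a hydrogen atom at this carbon would do the same.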